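Methoxy to chloro: what to expect for compound 3

This account rests on a few compounds, and the source may have more. Where it says the series, first, only, none or still open, it means among the compounds named here.

Measured in a functional assay on HUVEC cells (Homo sapiens) for antiproliferative activity, read by MTT assay, with a stated time of 48 h; on this read-out higher numbers stand for weaker inhibition and lower numbers for stronger inhibition:
- Compound 1 `Cc1ccc(/C=C/c2nnc(-c3ccc4c(c3)OCCO4)o2)cc1`: 45200 nM
- Compound 2 `COc1ccc(/C=C/c2nnc(-c3ccc4c(c3)OCCO4)o2)cc1`: > 50000 nM (a limit, not a number)

Compound 2 has no exact number and stands at the end of the measurable scale: the limit of > 50000 nM in this assay, at which 1 of the 2 values shown sits. The next compound, compound 3 `Clc1ccc(/C=C/c2nnc(-c3ccc4c(c3)OCCO4)o2)cc1`, changes one group of compound 2: chloro in place of methoxy on an aromatic carbon. This puts chloro in place of methoxy on an aromatic carbon, para to a large group. Within the data shown here, only one measured step bears on this, the methoxy in place of methyl change, which gave an at least 1.1-fold higher number from compound 1 to compound 2 (0.04 log units; that floor lies within the scatter). Among the measured compounds shown here, no measured step involves chloro, so the only guide is that compound 1 gives 45200 nM, and weak inhibition in this assay is expected to continue. No change beyond the scatter is expected, and the estimated step is an at least 1.2-fold lower number from compound 2 to compound 3 (0.09 log units; that floor lies within the scatter). The expected value for compound 3 is 40000 nM, within an estimated range of 15000 nM to 60000 nM.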

Compound 3, half-maximal inhibitory concentration: 8030 nM
The estimate for compound 3 lay 5.0-fold (0.70 log units) above the measured number, and the stated range ends above it.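

In this assay, the change to chloro gives an at least 6.2-fold lower number from compound 2 to compound 3 (0.79 log units; beyond the scatter), so the group on this aromatic carbon, para to a large group, can move the result beyond the scatter, which the methyl and methoxy pair could not show. The change from methyl is also clear, with a 5.6-fold lower number from compound 1 to compound 3 (0.75 log units; beyond the scatter), which makes compound 3 the strongest inhibitor of the three shown. The step from methoxy is only a floor, since compound 2 has a limit and not an exact number: the limit of > 50000 nM in this assay, at which 1 of the 3 values shown sits.

The compounds shown give no reason why chloro differs from methyl and methoxy here. They also leave open whether fluoro, bromo, a nitrile or an amine on this same carbon would match chloro, or whether chloro is a special case.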